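This account rests on a few compounds, and the source may have more. Where it says the series, first, only, none or still open, it means among the compounds named here.

Compound 1, `COc1cc2ccc(=O)oc2cc1OCCOc1no[n+]([O-])c1S(=O)(=O)c1ccccc1`: 3610 nM
Compound 2, `COc1cc2ccc(=O)oc2cc1OCCCCOc1no[n+]([O-])c1S(=O)(=O)c1ccccc1`: 3250 nM
Compound 3, `COc1cc2ccc(=O)oc2cc1OCCCCCCOc1c[n+]([O-])on1`: 3790 nM

Of the compounds shown here, three built on one shared core have been tested in a functional assay on HepG2 cells (Homo sapiens) for inhibition, read by MTT assay, with a stated time of 48 h; a higher number here means a weaker inhibitor, a lower number a stronger inhibitor. Compound 1 gives 3610 nM, compound 2 gives 3250 nM, and compound 3 gives 3790 nM. Compound 1 holds the second highest of these three numbers, but that ranking carries little meaning: its nearest neighbour, compound 3, and its furthest, compound 2, both lie within the usual scatter of repeated measurements, so the three values should be read as a single level rather than as a series of stronger and weaker inhibitors.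

Compound 4, `COc1cc2cc(NC(C)=O)c(=O)oc2cc1OCCOc1no[n+]([O-])c1S(=O)(=O)c1ccccc1`, has not yet been measured. It differs from compound 1 in exactly one place: acetamido in place of hydrogen on an aromatic carbon. For the measured compounds named here, none of the measured pairs tests this particular change, so there is no step in this assay from which to read its direction or size. The measured values only show that changes elsewhere on the core left the numbers essentially flat.

With nothing to anchor a shift, the change is expected to produce no step beyond the scatter, and the step from compound 1 to compound 4 is estimated at a 1.0-fold lower number from compound 1 to compound 4 (0.01 log units; within the scatter) in this assay. For compound 4 the expected value in this assay is 3500 nM, within a range from 1200 nM to 10000 nM.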

Compound 4, half-maximal inhibitory concentration: 4830 nM
Beside the measured number, compound 4's estimate is 1.4-fold (0.14 log units) below it; low and high end bracket the measured number.
By their numbers in this assay, from the lowest: compounds 2, 1, 3 and 4 (each within the scatter of the next).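

Placing acetamido in place of hydrogen on this aromatic carbon, two atoms from the ring oxygen, gives a 1.3-fold higher number from compound 1 to compound 4 (0.13 log units; within the scatter) in this assay. For the compounds shown here, this is the first direct test of this position, since the earlier compounds offered no single-place step from which to read it, and it shows that a hydrogen can give way to this much larger group without the number leaving the level shared by the other compounds. No measurement shown explains why the number stays at this level.

The compounds shown leave open whether an amine or a carboxylic acid on this same aromatic carbon would also stay within the scatter or would produce a real step. They also leave open whether acetamido at this position would behave the same way on compound 2, which carries a longer chain, or on compound 3, so this single step cannot yet be taken as a general rule for the shared core.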